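The source may hold more compounds than are shown below. What is called first, only, known or untested is meant among the compounds shown, and "the series" means these compounds.

Series notes. The shared core of compound 1 `CC(C)c1ccc(-n2nc(-c3ccc(C(F)(F)F)cc3O)nc2-c2ccccc2O)cc1` is kept through the set; the variation lies in the aryl group carried on the aromatic nitrogen. In a functional assay on PC-12 cells (Rattus norvegicus) for cytotoxicity, read by MTT assay, with stated times of 2 h and 24 h, tested at 1 uM (a lower number here means a weaker effect, a higher number a stronger effect of the compound at the concentration tested), compound 1 gives 69.7%. Compound 2 `COc1ccc(-n2nc(-c3ccc(C(F)(F)F)cc3O)nc2-c2ccccc2O)cc1` gives 69% in this assay, and compound 3 `Oc1cc(C(F)(F)F)ccc1-c1nc(-c2ccccc2O)n(-c2ccccc2C(F)(F)F)n1` gives 71%. Compound 1 sits second highest of the three, though all three values lie within the scatter of one another: the step of a number 0.7 percentage points lower from compound 1 to compound 2 (within the scatter) and the step of a number 1.3 percentage points higher from compound 1 to compound 3 (within the scatter) are both within the scatter, as is the step of a number 2 percentage points higher from compound 2 to compound 3 (within the scatter).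

Compound 4 `COc1cccc(-n2nc(-c3ccc(C(F)(F)F)cc3O)nc2-c2ccccc2O)c1` is not yet measured. The change from compound 1 is 3-methoxyphenyl in place of 4-isopropylphenyl on an aromatic nitrogen. Both measured steps at this same position bear on it, the step from compound 1 to compound 2 and the step from compound 1 to compound 3, and neither moved this assay beyond the scatter, whether the entering group was methoxy-bearing or trifluoromethyl-bearing. Nothing in the set therefore points to a step of any direction for compound 4; the expectation is of none beyond the scatter, with the step of a number 0.3 percentage points higher from compound 1 to compound 4 (within the scatter) expected to stay small. Compound 4 is estimated at 70% in this assay, within a range of 62% to 78%.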

Compound 4, a percentage reported as activity, at one concentration (the size of the read-out at that concentration, not a potency): 68.3%
Beside the measured number, compound 4's estimate is 1.7 percentage points above it; measured number inside the range.
By their numbers in this assay, from the lowest: compounds 4, 2, 1 and 3 (each within the scatter of the next).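

The new information lies in the methoxy pair: in this assay, 3-methoxyphenyl in place of 4-methoxyphenyl on the aromatic nitrogen gives a number 0.7 percentage points lower from compound 2 to compound 4 (within the scatter) and so adds a change in where the methoxy group sits on this aryl group to the changes of aryl group seen earlier. Within the data shown here, the other two comparisons at this position read the same way, with a number 1.4 percentage points lower from compound 1 to compound 4 (within the scatter) for 3-methoxyphenyl in place of 4-isopropylphenyl and a number 2.7 percentage points lower from compound 3 to compound 4 (within the scatter) for 3-methoxyphenyl in place of 2-(trifluoromethyl)phenyl, so compounds 1, 2, 3 and 4 form a set with no pair separated beyond the scatter and none of them goes against this reading. No supporting measurement is available to explain this lack of separation.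

Still open, on these data alone, is whether an aryl group bearing an amine or a carboxylic acid, or a longer alkyl chain in place of the aryl group on this nitrogen, would stay within the scatter of these four compounds. The compounds shown also keep the 2-hydroxyphenyl group fixed, so they leave open how replacing its hydroxyl with an amine would read in this assay.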